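Methoxy in place of methyl: an unmeasured step

The source may report more compounds than this note shows. Statements on the series, on what has been measured and on what is new or still open speak of the compounds shown alone.

Compound 1, `CN(C)C/C=C(/c1ccc(Cl)cc1)c1cccnc1`: in an in vivo functional assay on the whole organism (brain) for inhibition of Norepinephrine transporter (Rattus norvegicus) (a lower number here means that less compound is needed, a higher number that more compound is needed for the effect), compound 1 gives 38 umol/kg.
Compound 2, `CN(C)C/C=C(/c1ccc(I)cc1)c1cccnc1`: compound 2 reaches only a limit of this assay, > 88 umol/kg.
Compound 3, `Cc1ccc(/C(=C/CN(C)C)c2cccnc2)cc1`: compound 3 reaches only a limit of this assay, > 117 umol/kg.

Compound 3 thus stands at a limit, one of two such values here (the limit of > 117 umol/kg in this assay, at which 1 of the 3 values shown sits, (the limit of > 88 umol/kg in this assay, at which 1 of the 3 values shown sits)). Compound 4, `COc1ccc(/C(=C/CN(C)C)c2cccnc2)cc1`, differs from compound 3 by methoxy in place of methyl on an aromatic carbon. For the measured compounds named here, no measured step exchanges methyl for methoxy. The steps reaching compound 3 are an at least 3.0-fold higher number from compound 1 to compound 3 (0.48 log units; beyond the scatter), beside the related at least 2.3-fold higher number from compound 1 to compound 2 (0.36 log units; beyond the scatter), while a step that the two limits leave unreadable from compound 2 to compound 3. Since compound 3 is itself only a limit, the step to compound 4 is expected to be small and uncertain, a step that the limit leaves unreadable from compound 3 to compound 4. Compound 4 is therefore estimated at about 120 umol/kg, between 40 umol/kg and 350 umol/kg.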

Compound 4, dose for half-maximal effect: > 112 umol/kg
Compound 4: only a limit was reported; the forecaster's own chance of this, stated with the estimate: 55%; the middle value lies beyond the limit too.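

Compound 4 reaches only a limit in this assay, > 112 umol/kg. Exchanging chloro for methoxy on this aromatic carbon gives an at least 2.9-fold higher number from compound 1 to compound 4 (0.46 log units; beyond the scatter), so a group carrying a hydrogen-bond acceptor joins iodo and methyl, and all three replacements of chloro shown here move the same way. The steps among compound 2, compound 3 and compound 4 cannot be read, so these three groups cannot be ranked.

On these data alone, whether fluoro or bromo at this position would give a readable value stays open. So does the actual value of compound 4.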